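Swapping an anilide arm for a haloaryl ketone

The compounds below may be only part of what the source reports. "The series", "measured", "known", "first", "only" and "open" are said of these compounds alone.

Measured compounds:
compound 1 `O=C(NCCCCC(c1ccc(F)cc1)c1ccc(F)cc1)Nc1ccc([N+](=O)[O-])cc1` — 6470 nM
compound 2 `O=C(NCCCCCc1ccc(F)cc1)Nc1ccc(Cl)c(C(F)(F)F)c1` — 5440 nM
compound 3 `CN(CCCCC(c1ccc(F)cc1)c1ccc(F)cc1)C(=O)N(C)c1ccc(Cl)c(C(F)(F)F)c1` — only a limit, see below

In a functional assay on MDA-MB-231 cells (Homo sapiens) for cytotoxicity, read by MTT assay, with a stated time of 48 h (on this read-out higher numbers stand for weaker inhibition and lower numbers for stronger inhibition), compound 1 gives 6470 nM, the higher of the two numbers recorded. Compound 2 sits nearest with 5440 nM, and the gap between them lies within the usual scatter, so the two cannot be ordered. Compound 3 reaches only the assay limit of > 20000 nM, which is a limit and not a number (the limit of > 20000 nM in this assay, at which 1 of the 3 values shown sits).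

The step from compound 1 to the unmeasured compound 4 `O=C(NCCCCC(c1ccc(F)cc1)c1ccc(F)cc1)c1ccc(Cl)c(C(F)(F)F)c1` changes one place: 4-chloro-3-(trifluoromethyl)phenyl in place of (4-nitrophenyl)amino on a carbonyl carbon. For the measured compounds named here, the group that enters is the same one that compound 2 carries on its own nitrogen, yet here it sits directly on the carbonyl carbon, so no measured pair mirrors this step. In this assay no movement beyond the scatter is expected in either direction. Compound 4 is therefore estimated at 6000 nM, between 2500 nM and 15000 nM, which means an expected step of a 1.1-fold lower number from compound 1 to compound 4 (0.03 log units; within the scatter).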

Compound 4, half-maximal inhibitory concentration: 11700 nM
Compound 4: the middle estimate sits 2.0-fold (0.29 log units) below what was measured; measured number inside the range.
By their numbers in this assay, from the lowest: compounds 2, 1 and 4 (each within the scatter of the next, the first and the last beyond it). At a limit, above all of these: compound 3.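

In this assay, the change gives a 1.8-fold higher number from compound 1 to compound 4 (0.26 log units; within the scatter). For the compounds shown here, this is the first reading at this position on the carbonyl carbon, and it shows that the (4-nitrophenyl)amino arm, with its hydrogen-bond donor and two hydrogen-bond acceptors, can give way to 4-chloro-3-(trifluoromethyl)phenyl, which has none of these, without the number moving beyond the scatter. Compound 4 also still gives a number rather than a limit, so this arm's nitrogen is not needed for a measurable reading on this core. Nothing measured here gives a cause for this step.

The swap removes the nitrogen and changes the ring substituents together, so their separate contributions cannot be told apart. On these data alone, it remains open how this carbonyl carbon would read with an unsubstituted phenyl, a cyclic aliphatic amine such as morpholine, or a longer chain in this place.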